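Moving the hydroxyl on a terminal phenyl ring

The source may hold more compounds than are shown below. What is called first, only, known or untested is meant among the compounds shown, and "the series" means these compounds.

Of the compounds shown here, two have been tested in a functional assay on DU-145 cells (Homo sapiens) for cytotoxicity, read by CCK-8 assay; on this read-out lower numbers stand for stronger inhibition and higher numbers for weaker inhibition. Compound 1, `Oc1ccc(-c2cc(-c3cccs3)cc(-c3ccc(O)cc3)n2)cc1`, gives 2190 nM. Compound 2, `Oc1ccc(-c2cc(-c3cccnc3)cc(-c3ccccc3O)n2)cc1`, reaches only the limit of the assay, > 50000 nM. That the numbers for this pair include an assay limit is recorded as the limit of > 50000 nM in this assay, at which 1 of the 2 values shown sits, so compound 2 stands at the weak end of what has been measured, while compound 1 gives a genuine number. Within the data shown here, no single-point step connects compound 1 with compound 2, and the two values show only that one compound inhibits and the other does not within the tested range.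

Compound 3, `Oc1ccc(-c2cc(-c3cccnc3)cc(-c3ccc(O)cc3)n2)cc1`, has not yet been measured. It differs from compound 2 by 4-hydroxyphenyl in place of 2-hydroxyphenyl on an aromatic carbon. Compound 3 thereby carries the same two 4-hydroxyphenyl groups as compound 1, with a pyridin-3-yl group where compound 1 has a thiophen-2-yl group. Because compound 1 gives 2190 nM with that arrangement, compound 3 is expected to gain measurable potency, a step of an at least 6.2-fold lower number from compound 2 to compound 3 (0.79 log units; beyond the scatter) beyond the scatter. Compound 3 is therefore estimated at 8000 nM, within the range 2000 nM to 40000 nM.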

Compound 3, half-maximal inhibitory concentration: 240 nM
For compound 3 the middle estimate is 33-fold (1.52 log units) above the measured one, and the stated range ends above it.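

In this assay, moving the hydroxyl from 2-hydroxyphenyl to 4-hydroxyphenyl, with the same atoms joined differently, gives an at least 200-fold lower number from compound 2 to compound 3 (2.31 log units; beyond the scatter), so on this aromatic carbon next to the ring nitrogen, where the hydroxyl sits on the terminal ring decides between no measurable effect within the tested range and the strongest value of the three. On these data alone, the true size of this step stays unknown, since the value of compound 2 is a limit of the assay and not a number: the limit of > 50000 nM in this assay, at which 1 of the 3 values shown sits. Among these compounds, with 4-hydroxyphenyl on both sides, the other position also proves to matter, as pyridin-3-yl in place of thiophen-2-yl gives a 9.1-fold lower number from compound 1 to compound 3 (0.96 log units; beyond the scatter), a modest step but one that the single pair of earlier values could not reveal.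

The compounds shown leave open how 3-hydroxyphenyl would behave at this place, and whether the hydroxyl itself is needed, which a methoxy group or an amine in its stead would test. They also leave open whether the pyridin-3-yl group would keep its edge over thiophen-2-yl with 2-hydroxyphenyl on the core, or in any other cell line.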